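The source may report more compounds than this note shows. Statements on the series, on what has been measured and on what is new or still open speak of the compounds shown alone.

Working notes on the sulfur-linked heteroaryl series. Compound 1 `CCCCCCN(CCCCCSc1nc2ccccc2s1)C(=O)Nc1ccc(F)cc1F` gives 2730 nM in an assay on cells (Macrophage) for inhibition of sterol O-acyltransferase 1 (Mus musculus); on this read-out higher numbers stand for weaker inhibition and lower numbers for stronger inhibition. Among the compounds with values here, compound 2 `CCCCCCN(CCCCCSc1nc2cc([N+](=O)[O-])ccc2[nH]1)C(=O)Nc1ccc(F)cc1F` gives 8330 nM in this assay, and the step of a 3.1-fold higher number from compound 1 to compound 2 (0.48 log units; beyond the scatter) is the only one-place change measured so far: exchanging the heteroaryl group on the sulfur costs potency by a modest margin. Compound 3 `CCCCCCCN(CCCCCSc1ncccn1)C(=O)Nc1ccc(F)cc1F` gives 4370 nM in this assay; it sits second highest of the three numbers, within the scatter of compound 1 and also within the scatter of compound 2, so no order among the three can be called.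

Compound 4 `CCCCCCCN(CCCCCSc1[nH]cnc2ncnc1-2)C(=O)Nc1ccc(F)cc1F` is the next member; it differs from compound 3 by a group of 9 heavy atoms (5 carbon, 4 nitrogen; one five-membered aromatic ring with 2 hetero atoms, one six-membered aromatic ring with 2 hetero atoms) in place of a group of 6 heavy atoms (4 carbon, 2 nitrogen; one six-membered aromatic ring with 2 hetero atoms), on a sulfur. The step of a 3.1-fold higher number from compound 1 to compound 2 (0.48 log units; beyond the scatter) bears on it, since there too a larger heteroaryl carrying a ring hydrogen-bond donor replaced a smaller one on the sulfur, and the number rose modestly. The same direction is therefore expected here: a step of a 1.5-fold higher number from compound 3 to compound 4 (0.17 log units; within the scatter) that is at most modest and may not clear the scatter. Compound 4 is expected to give about 6500 nM in this assay, with a plausible range from 2500 nM to 17000 nM.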

Compound 4, half-maximal inhibitory concentration: 5320 nM
For compound 4 the middle estimate is 1.2-fold (0.09 log units) above the measured one, and the stated range covers the measured number.
By their numbers in this assay, from the lowest: compounds 1, 3, 4 and 2 (each within the scatter of the next, the first and the last beyond it).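

On the sulfur whose other neighbour is a saturated chain carbon, the pyrimidin-2-yl group gives way to a group of 9 heavy atoms, with a five-membered and a six-membered aromatic ring and 1 hydrogen-bond donor, and this assay shows no readable change: a 1.2-fold higher number from compound 3 to compound 4 (0.09 log units; within the scatter). Within the data shown here, at this place, then, the second aromatic ring and the ring donor do not by themselves bring a loss in this pair, whereas the only other one-place step, a 3.1-fold higher number from compound 1 to compound 2 (0.48 log units; beyond the scatter), lies beyond the scatter, so a larger heteroaryl group carrying a donor does not give a readable loss in every case. No measurement at hand accounts for the difference between these two steps.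

Compound 1 and compound 3 differ in two places, so the compounds shown do not separate the effect of the heteroaryl group from that of the chain on the nitrogen. As far as these compounds go, how a pyridin-2-yl or a plain phenyl group on the sulfur would read against these values remains open, as does the effect of an amine or a carboxylic acid on the heteroaryl group.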